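This account rests on a few compounds, and the source may have more. Where it says the series, first, only, none or still open, it means among the compounds named here.

In a functional assay on SF-539 cells (Homo sapiens) for inhibition, read by sulforhodamine B assay, with a stated time of 48 h, tested at 10 uM (on this read-out lower numbers stand for less inhibition of growth and higher numbers for more inhibition of growth at the one concentration tested), compound 1 (`COc1ccc(-c2nc3sc(-c4ccccc4)cn3n2)cc1`) gives 24% and stands level with compound 2 (`COc1cc(-c2nc3sc(-c4ccccc4)cn3n2)cc(OC)c1OC`), which gives 15% and lies within the usual scatter of repeated measurements. Compound 3 (`COc1cc(-c2nc(N)n(CC(=O)Nc3ccc(/C(C)=N\O)cc3)n2)cc(OC)c1OC`) gives 2.92% and lies lower than compound 1 by more than that scatter. So compound 1 sits among the higher numbers of this small set, though only three compounds are there to compare.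

Compound 4 (`COc1ccc(-c2nc3sc(-c4ccc(Cl)cc4)cn3n2)cc1`) has not been measured yet. It differs from compound 1 by a single change (chloro in place of hydrogen on an aromatic carbon): phenyl becomes 4-chlorophenyl, with chloro in place of hydrogen on an aromatic carbon. Among the compounds with values here, no measured pair of compounds shows this swap, so the data offer no direct guide to its size or direction, and a cautious expectation is the only honest one. The expected change (a number 6 percentage points higher from compound 1 to compound 4 (within the scatter)) is small, upward if anything, and stays within the scatter. For compound 4 the estimated value is 30% with an expected range from 12% to 52% as the likely span.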

Compound 4, percent growth inhibition at one concentration: 84.6%
Beside the measured number, compound 4's estimate is 54.6 percentage points below it; the whole stated range lies below it.
By their numbers in this assay, from the lowest: compound 3; then compounds 2 and 1 (each within the scatter of the next); then compound 4.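

In this assay the change of phenyl to 4-chlorophenyl, chloro in place of hydrogen on an aromatic carbon, gives a number 60.6 percentage points higher from compound 1 to compound 4 (beyond the scatter) and is a large step. Within the data shown here, this is the first pair in the set that differs in one place, and it shows that this position is far from silent: a single added chlorine atom, placed para to a large group, is enough to move growth inhibition a long way at the one concentration tested. Nothing available here accounts for the size of this step.

As far as these compounds go, whether the gain belongs to chloro itself stays open, and a fluoro, a methyl, a methoxy or a carboxylic acid on the same carbon would help to settle it. From the compounds shown here alone, whether chloro would do the same on compound 2 also stays open.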